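The source may hold more compounds than are shown below. What is called first, only, known or untested is meant among the compounds shown, and "the series" means these compounds.

Measured in a functional assay on KB cells (Homo sapiens) for cytotoxicity, read by resazurin assay, with a stated time of 3 days; on this read-out lower numbers stand for stronger inhibition and higher numbers for weaker inhibition:
- compound 1 `CCCC(C)C(=O)NCC(C)(C)CC1=C(O)C(=O)c2ccccc2C1=O`: 47100 nM
- compound 2 `CCCCCC(=O)NCC(C)(C)CC1=C(O)C(=O)c2ccccc2C1=O`: 40200 nM
- compound 3 `CCCCCCCCCC(=O)NCC(C)(C)CC1=C(O)C(=O)c2ccccc2C1=O`: 18500 nM

Compound 3 holds the lowest number of the three and is set apart from both others beyond the scatter: a 2.2-fold lower number from compound 2 to compound 3 (0.34 log units; beyond the scatter) and a 2.5-fold lower number from compound 1 to compound 3 (0.41 log units; beyond the scatter). The remaining pair lies within the scatter of each other: a 1.2-fold lower number from compound 1 to compound 2 (0.07 log units; within the scatter).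

Compound 4 `CCCCCCCCCCCCCC(=O)NCC(C)(C)CC1=C(O)C(=O)c2ccccc2C1=O` carries the chain of compound 3 further out: butyl in place of hydrogen on a saturated chain carbon, nine bonds along the chain from a carbonyl carbon. For the measured compounds named here, the one measured step of the same kind is a 2.2-fold lower number from compound 2 to compound 3 (0.34 log units; beyond the scatter), likewise an entering butyl, and a 2.5-fold lower number from compound 1 to compound 3 (0.41 log units; beyond the scatter) points the same way. Going by the values given here, on that basis a further modest lowering of the number is expected, with the caveat that a single precedent gives no assurance that the same size repeats once more along the chain, and no measured compound shows where such a run levels off. The step from compound 3 to compound 4 is therefore estimated at a 1.9-fold lower number from compound 3 to compound 4 (0.27 log units; within the scatter). Compound 4 is expected to give 10000 nM, within a range from 4500 nM to 25000 nM.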

Compound 4, half-maximal inhibitory concentration: 25100 nM
Estimate against measurement, compound 4: 2.5-fold (0.40 log units) below, outside the stated range (above it).
By their numbers in this assay, from the lowest: compounds 3, 4, 2 and 1 (each within the scatter of the next, the first and the last beyond it).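

In this assay, butyl entering on a saturated chain carbon, nine bonds along the chain from a carbonyl carbon, does not repeat the step seen at five bonds along the chain, which stays beyond the scatter at a 2.2-fold lower number from compound 2 to compound 3 (0.34 log units; beyond the scatter); here the result is a 1.4-fold higher number from compound 3 to compound 4 (0.13 log units; within the scatter). Octyl at the five-bond place likewise gives a 1.6-fold lower number from compound 2 to compound 4 (0.20 log units; within the scatter), so compound 4 lies within the scatter of both compound 2 and compound 3, and the series shows no measured gain from this chain extension. No supporting measurement accompanies these numbers to account for the result.

Going by these compounds, whether an amine or a carboxylic acid in place of butyl at this position would move the number beyond the scatter remains open. So does the behaviour of a longer chain than that of compound 4.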